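A few compounds are considered here, and "the series" means these few. Any claim that something is new, unique, unknown or untested is made for them only; others in the source may bear on it.

Measured in a functional assay on MCF7 cells (Homo sapiens) for antiproliferative activity, read by sulforhodamine B assay, with a stated time of 48 h; a lower number here means a stronger inhibitor, a higher number a weaker inhibitor:
- compound 1 `COc1ccc(/C=C/C(=O)c2ccccc2-c2cccc(F)c2)cc1`: 640 nM
- compound 2 `COc1ccc(/C=C/C(=O)c2ccccc2-c2cccnc2)cc1`: 830 nM
- compound 3 `COc1ccc(C(=O)/C=C/c2ccccc2-c2ccc(F)cc2)cc1`: 8800 nM

Compound 3 has the highest number of the three, and its gaps to compound 1 and compound 2 both lie beyond the scatter. Compound 4 `COc1ccc(C(=O)/C=C/c2ccccc2-c2ccc(F)nc2)cc1` differs from it as follows: 6-fluoropyridin-3-yl in place of 4-fluorophenyl on an aromatic carbon. This is 6-fluoropyridin-3-yl in place of 4-fluorophenyl, ortho to a large group. For the measured compounds named here, the one measured step that bears on this is a related exchange on a different core, a 1.3-fold higher number from compound 1 to compound 2 (0.11 log units; within the scatter). That step lies within the scatter, so no step beyond the scatter is expected in this assay. The expected change is a 1.3-fold lower number from compound 3 to compound 4 (0.10 log units; within the scatter). The estimated value for compound 4 is 7000 nM, with an expected range of 2500 nM to 20000 nM.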

Compound 4, half-maximal inhibitory concentration: 13000 nM
Compound 4: the middle estimate sits 1.9-fold (0.27 log units) below what was measured, within the range that was stated.
By their numbers in this assay, from the lowest: compounds 1 and 2 (each within the scatter of the next); then compounds 3 and 4 (each within the scatter of the next).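

In this assay, 6-fluoropyridin-3-yl in place of 4-fluorophenyl, ortho to a large group, gives a 1.5-fold higher number from compound 3 to compound 4 (0.17 log units; within the scatter), so a ring nitrogen in this aryl group leaves the number within the scatter on this core with the fluorine retained. The related exchange on the core of compound 1 also stayed within the scatter, with a 1.3-fold higher number from compound 1 to compound 2 (0.11 log units; within the scatter). No measurement at hand explains either step.

Open, from the compounds shown here alone, is whether an amine or a methoxy group in place of the fluorine of 6-fluoropyridin-3-yl would move the number beyond the scatter. Also open, going by these compounds, is how 6-fluoropyridin-3-yl behaves on the core of compound 1.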